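Pentylamino in Place of Chloro: Cytotoxicity Outlook

The source may report more compounds than this note shows. Statements on the series, on what has been measured and on what is new or still open speak of the compounds shown alone.

Compound 1 `CCCCCCCCNc1nccnc1C(=O)NCc1ccccc1`. In an ADME assay on HeLa cells (Homo sapiens) for cytotoxicity, read by microscopy, with a stated time of 6 days (on this read-out higher numbers stand for lower toxicity in this test and lower numbers for higher toxicity in this test), compound 1 gives > 100000 nM, which is a limit of the assay rather than a number.
Compound 2 `O=C(NCc1ccccc1)c1nccnc1Cl`. In this assay compound 2 gives "not determined" (no result reported).

Compound 2 therefore stands without a number of its own; of the two values shown, one sits at the limit of > 100000 nM in this assay, at which 1 of the 2 values shown sits. Compound 3 `CCCCCNc1nccnc1C(=O)NCc1ccccc1` differs from compound 2 by pentylamino in place of chloro on an aromatic carbon. Among the measured compounds shown here, no measured step between compounds is available to size this change, so in this assay any shift is expected to be small, none beyond the scatter, with no clear direction. Compound 3 is expected to give about 100000 nM, from 30000 nM to 300000 nM.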

Compound 3, minimum cytotoxic concentration: > 100000 nM
Compound 3 gave a limit, no number (the forecaster's own chance of this, stated with the estimate: 80%); the middle value lies on the limit itself.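

Compound 1 and compound 3 both give limits of the assay rather than numbers, and compound 2 has no reported result, so no step can be read among them. As far as these compounds go, whether chain length, or pentylamino in place of chloro, changes the reading in this assay stays open.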